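A few compounds are considered here, and "the series" means these few. Any claim that something is new, unique, unknown or untested is made for them only; others in the source may bear on it.

Working notes on the series in an in vitro ADME assay on microsomes from liver (Rattus norvegicus) for metabolic stability; a lower number here means slower removal, a higher number faster removal of the compound.

Two compounds carry a number. Compound 1 `Cc1cc(C(=O)NCc2ccccn2)nn1Cc1cc(Cl)ccc1OCc1ccccc1` gives 30 mL.min-1.g-1 in this assay. Compound 2 `Cc1cc(NC(=O)C2CCCCC2)nn1Cc1cc(Cl)ccc1OCC(C)C` gives 15 mL.min-1.g-1 in this assay. Compound 1 has the highest of the two numbers, but its nearest neighbour, compound 2, sits only a little way off and the gap between the two falls within the scatter of repeated measurements, so no order between them can be read from these numbers. Among the measured compounds shown here, compound 1 and compound 2 also differ in more than one place, so their pair gives no step that could be carried over to a new compound.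

Compound 3 `Cc1cc(NC(=O)OCc2ccccn2)nn1Cc1cc(Cl)ccc1OCc1ccccc1` is the next compound to be measured. It differs from compound 1 in one place: (((pyridin-2-yl)methoxy)carbonyl)amino in place of ((pyridin-2-yl)methyl)carbamoyl on an aromatic carbon. For the measured compounds named here, no measured pair shows a change of this kind, so the step is expected to be small, of a size a 1.2-fold higher number from compound 1 to compound 3 (0.07 log units; within the scatter), and no firm direction beyond the scatter is expected. Compound 3 is therefore estimated at 35 mL.min-1.g-1, within a range from 15 mL.min-1.g-1 to 80 mL.min-1.g-1.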

Compound 3, intrinsic clearance in microsomes: 8.4 mL.min-1.g-1
The estimate for compound 3 lay 4.2-fold (0.62 log units) above the measured number; the whole stated range lies above it.
By their numbers in this assay, from the lowest: compounds 3, 2 and 1 (each within the scatter of the next, the first and the last beyond it).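

In this assay, among the compounds shown here, the first one-place change gives a 3.6-fold lower number from compound 1 to compound 3 (0.55 log units; beyond the scatter) at this position, on an aromatic carbon of the five-membered aromatic ring. Exchanging ((pyridin-2-yl)methyl)carbamoyl for (((pyridin-2-yl)methoxy)carbonyl)amino is therefore not neutral here, even though both groups carry the same six-membered aromatic ring with 1 hetero atom and the rest of the core of compound 1 stays in place. Nothing shown bears on the reason for this step.

As far as these compounds go, a single pair cannot separate the parts of the exchange, so it remains open whether the step follows from the reversed order of the atoms joining the carbonyl to the ring or from the oxygen in the entering group, which has 2 oxygen atoms against 1 in the group it replaces. A urea with an amine nitrogen in place of that oxygen, or a longer chain before the pyridin-2-yl ring, would test this, and whether the step carries over to cores with other groups is also unresolved.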